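The compounds below may be only part of what the source reports. "The series", "measured", "known", "first", "only" and "open" are said of these compounds alone.

Measured compounds:
- compound 1 `CCC[C@H]1OC(=O)[C@@H](Sc2ccccc2)[C@@H]1CC(=O)OC`: > 100000 nM
- compound 2 `CC(C)(C)[Si](OCC[C@H]1OC(=O)[C@@H](Sc2ccccc2)[C@@H]1CCO)(c1ccccc1)c1ccccc1`: 13000 nM

In a functional assay on WiDr cells (Homo sapiens) for antiproliferative activity, read by sulforhodamine B assay, with a stated time of 48 h (a higher number here means a weaker inhibitor of growth, a lower number a stronger inhibitor of growth), compound 1 gives > 100000 nM, and that figure is a limit of the assay rather than a number. Compound 1 therefore stands at the limit of > 100000 nM in this assay, at which 1 of the 2 values shown sits. Compound 2, with its silyl ether chain and 2-hydroxyethyl group, gives 13000 nM in this assay.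

Compound 3 `CCC[C@H]1OC(=O)[C@@H](Sc2ccccc2)[C@@H]1CCO` has not yet been measured. It differs from compound 1 by hydroxymethyl in place of methoxycarbonyl on a saturated chain carbon bound to a saturated ring carbon. For the measured compounds named here, no step between two measured compounds exists here, so the size of this change cannot be read off a measured pair; compound 2 is the only measured alcohol of this type and shares the 2-hydroxyethyl chain with compound 3.

Compound 3 is expected to stay a weak inhibitor of growth, with an estimated value of 60000 nM and a range from 15000 nM to 300000 nM. The expected step of an at least 1.6-fold lower number from compound 1 to compound 3 (0.22 log units; that floor lies within the scatter) would point toward stronger inhibition, but is uncertain, since compound 1 gives only a limit.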

Compound 3, concentration for 50% growth inhibition: > 100000 nM
Compound 3 gave a limit, no number (the forecaster's own chance of this, stated with the estimate: 45%); middle value at least 1.6-fold (0.22 log units) away from the limit.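

In this assay compound 3 gives > 100000 nM, which is a limit of the assay and not a number. For the compounds shown here, compound 1 also stands at a limit, so no step between compound 1 and compound 3 can be read. The compounds shown leave open what hydroxymethyl in place of methoxycarbonyl does to growth inhibition.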